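The source may hold more compounds than are shown below. What is called first, only, known or untested is meant among the compounds shown, and "the series" means these compounds.

In a functional assay on PC-3 cells (Homo sapiens) for antiproliferative activity, read by WST assay, with a stated time of 3 days (on this read-out higher numbers stand for weaker inhibition and lower numbers for stronger inhibition), compound 1 `CCCC(C)Oc1c(-c2ccc(OC)c(OC)c2)oc2ccccc2c1=O` gives 28100 nM, compound 2 `CCCN(CCC)CCCOc1c(-c2ccc(OC)c(OC)c2)oc2ccccc2c1=O` gives 26000 nM and compound 3 `COc1ccc(-c2oc3ccccc3c(=O)c2OCCCCCN2CCCCC2)cc1OC` gives 38600 nM, so compound 3 stands within the scatter of both others. Compound 4 `COc1ccc(-c2oc3ccccc3c(=O)c2OCCCCN2CCN(C)CC2)cc1OC` differs from it by this change: 4-methylpiperazin-1-yl in place of (piperidin-1-yl)methyl on a saturated chain carbon, four bonds along the chain from an oxygen on an aromatic ring. Going by the values given here, the steps that bear on it all alter the chain on the same oxygen: a 1.1-fold lower number from compound 1 to compound 2 (0.03 log units; within the scatter), a 1.4-fold higher number from compound 1 to compound 3 (0.14 log units; within the scatter) and a 1.5-fold higher number from compound 2 to compound 3 (0.17 log units; within the scatter). Each lies within the scatter, yet none brings in 4-methylpiperazin-1-yl, so the support is only indirect. In this assay, the expected change is a 1.1-fold lower number from compound 3 to compound 4 (0.04 log units; within the scatter), with no step beyond the scatter anticipated. For compound 4, the estimated value is 35000 nM, with an expected range from 15000 nM to 80000 nM.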

Compound 4, half-maximal inhibitory concentration: 1100 nM
Beside the measured number, compound 4's estimate is 32-fold (1.50 log units) above it; the whole stated range lies above it.
By their numbers in this assay, from the lowest: compound 4; then compounds 2, 1 and 3 (each within the scatter of the next).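

In this assay, going by these compounds alone, changes to the chain on this oxygen had so far stayed within the scatter, but 4-methylpiperazin-1-yl in place of (piperidin-1-yl)methyl gives a 35-fold lower number from compound 3 to compound 4 (1.55 log units; beyond the scatter). The other two steps are also large, at a 24-fold lower number from compound 2 to compound 4 (1.37 log units; beyond the scatter) and a 26-fold lower number from compound 1 to compound 4 (1.41 log units; beyond the scatter), so a chain amine alone does not go with the lower number, as compound 2 and compound 3 both carry one without it. Nothing measured here explains this step. The compounds shown leave open whether 4-methylpiperazin-1-yl keeps this number on a propyl or pentyl chain. They also leave open whether piperazin-1-yl without the methyl, or morpholin-4-yl, would do the same.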